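The source may report more compounds than this note shows. Statements on the series, on what has been measured and on what is new or still open speak of the compounds shown alone.

In an ADME assay on microsomes from liver (Mus musculus) for metabolic stability, read by LC-MS, with a stated time of 10 min (a higher number here means that more of the compound is left, a lower number that less of the compound is left), compound 3 `CN(C[C@H]1Cc2c(cccc2N2CCN(c3cccc(C(F)(F)F)c3)CC2)CN1)[C@H]1CCCc2cccnc21` gives 72.3%, the highest of the three values and beyond the scatter of the other two. Compound 1 `CN(C[C@H]1Cc2c(cccc2N2CCNC(C)(C)C2)CN1)[C@H]1CCCc2cccnc21` gives 44%, and compound 2 `CN(C[C@H]1Cc2c(cccc2N2CCN3CCC[C@H]3C2)CN1)[C@H]1CCCc2cccnc21` gives 40.1%. Compound 4 `CN1CCN(c2cccc3c2C[C@H](CN(C)[C@H]2CCCc4cccnc42)NC3)CC1` departs from compound 3 by methyl in place of 3-(trifluoromethyl)phenyl on an amine nitrogen in a ring. Within the data shown here, no measured step makes this exact change. The closest evidence is a number 3.9 percentage points lower from compound 1 to compound 2 (within the scatter), a small step between two compounds that both lack the 3-(trifluoromethyl)phenyl. Compound 4 also lacks it, so a drop beyond the scatter is expected, with the estimated step being a number 29.3 percentage points lower from compound 3 to compound 4 (beyond the scatter). Compound 4 is estimated at 43%, with an expected range from 25% to 62%.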

Compound 4, percent of the compound remaining: 17%
Compound 4: the middle estimate sits 26 percentage points above what was measured; the whole stated range lies above it.
By their numbers in this assay, from the lowest: compound 4; then compounds 2 and 1 (each within the scatter of the next); then compound 3.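

In this assay methyl in place of 3-(trifluoromethyl)phenyl on this amine nitrogen in a ring costs much of the compound left (a number 55.3 percentage points lower from compound 3 to compound 4 (beyond the scatter)), so this nitrogen's substituent strongly shapes the read-out. The methylated group also falls short of the other two groups on the aromatic carbon (a number 27 percentage points lower from compound 1 to compound 4 (beyond the scatter); a number 23.1 percentage points lower from compound 2 to compound 4 (beyond the scatter)), so the high number of compound 3 is not simply restored by any small group. Nothing measured here gives a reason for these drops. Going by these compounds, a plain phenyl or a pyridine on this nitrogen remains open, as does the part the trifluoromethyl plays apart from its ring.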